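Trimming the ethyl on the hydroxylated urea nitrogen

The source may report more compounds than this note shows. Statements on the series, on what has been measured and on what is new or still open speak of the compounds shown alone.

Measured so far:
compound 1 `CCCNC(=O)N(O)c1cc([C@H]2CC[C@H](c3cc(OC)c(OC)c(OC)c3)O2)cc(OCCC)c1OCCC`: 91 nM
compound 2 `CCCOc1c(NC(=O)N(O)C(C)CC)cc(C2CCC(c3cc(OC)c(OC)c(OC)c3)O2)cc1OC`: 25 nM; 1610 nM (2 entries)
compound 3 `CCCOc1cc([C@H]2CC[C@H](c3cc(OC)c(OC)c(OC)c3)O2)cc(N(CC)C(=O)N(O)CC)c1OCCC`: 17 nM
compound 4 `CCCOc1cc([C@H]2CC[C@H](c3cc(OC)c(OC)c(OC)c3)O2)cc(N(CC)C(=O)N(C)O)c1OCCC`: not yet measured

In an assay for binding affinity to platelet-activating factor receptor (Homo sapiens) (a higher number here means a weaker inhibitor, a lower number a stronger inhibitor), compound 3 gives 17 nM, the lowest of the two single numbers in the set. Among the measured compounds shown here, compound 1 gives 91 nM, and the step of a 5.4-fold lower number from compound 1 to compound 3 (0.73 log units; beyond the scatter) is the only single-change step available. Compound 2 has two entries that lie far apart the several entries of compound 2 in this assay, 25 nM; 1610 nM (2 entries) and offers no single number to rank against.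

The change from compound 3 to compound 4 is hydrogen in place of methyl on a saturated chain carbon bound to an amide-type nitrogen. It shortens the alkyl on the hydroxylated urea nitrogen by one carbon and leaves the ring, the ethyl on the other nitrogen and the three propoxy and methoxy groups untouched. For the measured compounds named here, the only measured step, from compound 1 to compound 3, rewrote both urea nitrogens at once, so it bears on this change only loosely; no measured step isolates a one-carbon change on this chain. A small step is therefore expected in this assay, likely within the scatter, with a slight drift to a higher number if anything. Compound 4 is expected at 25 nM, range 10 nM to 70 nM, which means the step of a 1.5-fold higher number from compound 3 to compound 4 (0.17 log units; within the scatter) is estimated to stay inside the scatter.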

Compound 4, half-maximal inhibitory concentration: 68 nM
The estimate for compound 4 lay 2.7-fold (0.43 log units) below the measured number; low and high end bracket the measured number.
By their numbers in this assay, from the lowest: compound 3; then compounds 4 and 1 (each within the scatter of the next).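

The one-carbon trim on the hydroxylated urea nitrogen is now isolated: in this assay, ethyl to methyl gives a 4.0-fold higher number from compound 3 to compound 4 (0.60 log units; beyond the scatter) and so lies beyond the scatter, which shows that this chain position is not indifferent to a single carbon. The earlier step of a 5.4-fold lower number from compound 1 to compound 3 (0.73 log units; beyond the scatter) changed both urea nitrogens at once and could not show this. The new comparison a 1.3-fold lower number from compound 1 to compound 4 (0.13 log units; within the scatter) stays within the scatter, so among these three compounds the rewritten urea stands clear of compound 1 only with ethyl on the hydroxylated nitrogen, as in compound 3, and not with methyl, as in compound 4.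

The compounds shown leave open whether a longer chain such as propyl, or a branched isopropyl group, on the hydroxylated urea nitrogen would continue the trend from methyl to ethyl or reverse it. Nothing in the data available accounts for the size of this one-carbon step.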